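This account rests on a few compounds, and the source may have more. Where it says the series, first, only, none or still open, it means among the compounds named here.

In a functional assay on cells (Cancer cell lines, Homo sapiens) for inhibition (on this read-out higher numbers stand for weaker inhibition of growth and lower numbers for stronger inhibition of growth), compound 2 (`N=C(N)N/N=C/c1c(-c2cccs2)nc2sccn12`) gives 21900 nM and compound 1 (`Cc1cn2c(/C=N/NC(=N)N)c(-c3ccsc3)nc2s1`) gives 28200 nM on the same read-out. These two numbers lie within the usual scatter of each other, so compound 2 sits level with compound 1 and neither can be ranked above the other.

Compound 3 (`Cc1cn2c(/C=N/NC(=N)N)c(-c3cccs3)nc2s1`) comes from compound 2 by one small edit: methyl in place of hydrogen on an aromatic carbon of the five-membered aromatic ring with 1 nitrogen and 1 sulfur, next to the ring sulfur (methyl in place of hydrogen on an aromatic carbon). Going by the values given here, no measured pair shows this change on its own, so the data offer no direct guide to its effect.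

The only anchor is the narrow spread of the two numbers already in hand, and no shift beyond the scatter is expected in either direction. The expected 1.1-fold higher number from compound 2 to compound 3 (0.04 log units; within the scatter) is therefore small. For compound 3 the estimated value in this assay is 24000 nM with an expected range from 11000 nM to 50000 nM in repeated measurements.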

Compound 3, concentration for total growth inhibition: 14100 nM
Compound 3: the middle estimate sits 1.7-fold (0.23 log units) above what was measured; the measured number falls inside the stated range.
By their numbers in this assay, from the lowest: compounds 3, 2 and 1 (each within the scatter of the next).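

In this assay, methyl in place of hydrogen on an aromatic carbon, next to the ring sulfur, gives a 1.6-fold lower number from compound 2 to compound 3 (0.19 log units; within the scatter) and so stays within the usual scatter; this first direct view of the position shows that adding this one small group leaves the number indistinguishable from that of the parent compound. The second step concerns the thiophene ring in the methyl series: thiophen-2-yl in place of thiophen-3-yl on an aromatic carbon gives a 2.0-fold lower number from compound 1 to compound 3 (0.30 log units; within the scatter) and also stays within the scatter, so on this read-out the two ways of attaching the thiophene cannot be told apart. Nothing in the available data explains either step or says what lies behind these small differences.

As far as these compounds go, whether a longer chain such as ethyl, or a different kind of group such as an amine or a carboxylic acid, at this same carbon would shift the number beyond the scatter remains open. From the compounds shown here alone, it is also open whether the methyl step would read the same with thiophen-3-yl in place of thiophen-2-yl on the shared core.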